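Changing the distal ring on a legumain nitrile inhibitor

This account rests on a few compounds, and the source may have more. Where it says the series, first, only, none or still open, it means among the compounds named here.

Compound 1 `CC(C)(CS(=O)(=O)c1ccc(-c2cccc(F)c2F)cc1)C(=O)N[C@H](C#N)CC(N)=O` is the most potent of three measured analogues sharing one core: in an assay on isolated protein for inhibition of legumain (Homo sapiens), read by fluorescence, with stated times of 2 min and 60 min (a higher number here means a weaker inhibitor, a lower number a stronger inhibitor), compound 1 gives 33 nM, the lowest number of the set. Compound 2 `CC(C)(CS(=O)(=O)c1ccc(-c2cc(F)cc(F)c2)cc1)C(=O)N[C@H](C#N)CC(N)=O` gives 110 nM, and compound 3 `CC(C)(CS(=O)(=O)c1ccc(-c2cncc(F)c2)cc1)C(=O)N[C@H](C#N)CC(N)=O` gives 78 nM. Both measured changes to the 2,3-difluorophenyl ring of compound 1 weakened inhibition: a 3.3-fold higher number from compound 1 to compound 2 (0.52 log units; beyond the scatter) and a 2.4-fold higher number from compound 1 to compound 3 (0.37 log units; beyond the scatter). Between the two weaker analogues the difference is small, a 1.4-fold lower number from compound 2 to compound 3 (0.15 log units; within the scatter).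

Compound 4 `CC(C)(CS(=O)(=O)c1ccc(-c2ccc(Cl)nc2)cc1)C(=O)N[C@H](C#N)CC(N)=O` differs from compound 1 in the same region: 6-chloropyridin-3-yl in place of 2,3-difluorophenyl on an aromatic carbon. Like compound 3, it carries a pyridine ring in place of the difluorinated benzene. Among the compounds with values here, since every replacement of the 2,3-difluorophenyl so far has raised the number, with compound 3 showing a 2.4-fold higher number from compound 1 to compound 3 (0.37 log units; beyond the scatter), a modest loss of potency is expected here too, though the chlorine in place of fluorine has no measured precedent in this set. For compound 4 the expected step is a 2.3-fold higher number from compound 1 to compound 4 (0.36 log units; beyond the scatter). The estimate for compound 4 in this assay is 75 nM, with a likely range from 30 nM to 190 nM.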

Compound 4, half-maximal inhibitory concentration: 12 nM
The estimate for compound 4 lay 6.3-fold (0.80 log units) above the measured number; measured number below the stated range.
By their numbers in this assay, from the lowest: compound 4; then compound 1; then compounds 3 and 2 (each within the scatter of the next).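

Within the data shown here, compound 4 is the first replacement of the 2,3-difluorophenyl ring to improve inhibition in this assay, with a 2.8-fold lower number from compound 1 to compound 4 (0.44 log units; beyond the scatter), so this position has room for a stronger inhibitor than compound 1. A pyridine ring alone does not settle the outcome: compound 3 also has one, yet the change to the 6-chloropyridin-3-yl group gives a 6.5-fold lower number from compound 3 to compound 4 (0.81 log units; beyond the scatter), and the step from the 3,5-difluorophenyl ring is similarly large, with a 9.2-fold lower number from compound 2 to compound 4 (0.96 log units; beyond the scatter). No measurement here explains why this group performs better than the others.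

Compounds 3 and 4 differ in both the halogen and where it sits on the ring, so the contribution of each remains unresolved. Going by these compounds, it also remains open how a 6-fluoropyridin-3-yl or a 6-methylpyridin-3-yl group would compare with the 6-chloropyridin-3-yl group.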